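Adding a second hydroxyl to the side chain of a brominated core

The compounds below may be only part of what the source reports. "The series", "measured", "known", "first", "only" and "open" are said of these compounds alone.

Measured so far:
- compound 1, `C[C@@H](O)CCn1nc2c(Br)c(Br)c(Br)c(Br)c2n1`, 77%
- compound 2, `CC(O)CCn1nc2c(Br)c(Br)c(Br)c(Br)c2n1`, 73%

Both compounds share the same brominated core and a short hydroxylated chain on one of its nitrogen atoms. In a functional assay on MCF7 cells (Homo sapiens) for antiproliferative activity, read by MTT assay, with a stated time of 48 h, tested at 25 uM (on this read-out higher numbers stand for a weaker effect at the one concentration tested and lower numbers for a stronger effect), compound 1 gives 77%, and compound 2 gives 73%. The two differ only in the drawing of one stereocentre, as the fact that one of compounds 1 and 2 is drawn with a defined configuration and the other without, at the place where they differ shows, and the step of a number 4 percentage points lower from compound 1 to compound 2 (within the scatter) lies within the scatter. Compound 2 therefore stands alongside compound 1 with no real separation between the two.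

Compound 3, `OCC(O)Cn1nc2c(Br)c(Br)c(Br)c(Br)c2n1`, is not yet measured. It differs from compound 2 by 1,2-dihydroxyethyl in place of 2-hydroxypropyl on a saturated chain carbon bound to an aromatic nitrogen. Among the compounds with values here, no measured step involves a change of this kind: the only step available concerns stereochemistry and says nothing about exchanging a methyl-bearing hydroxylated chain for a chain carrying two hydroxyls. Since both measured compounds sit close together, the most defensible expectation is that compound 3 behaves similarly, with a step of a number 2 percentage points higher from compound 2 to compound 3 (within the scatter), which is expected to fall within the scatter. Compound 3 is thus estimated at 75%, with a range from 55% to 92%.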

Compound 3, a percentage reported as activity, at one concentration (the size of the read-out at that concentration, not a potency): 111%
For compound 3 the middle estimate is 36 percentage points below the measured one; measured number above the stated range.
By their numbers in this assay, from the lowest: compounds 2 and 1 (each within the scatter of the next); then compound 3.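

The earlier compounds shown here showed only that the way the stereocentre is drawn leaves the result in this assay within the scatter, but the composition of the chain at this position clearly matters. Placing 1,2-dihydroxyethyl in place of 2-hydroxypropyl on a saturated chain carbon bound to an aromatic nitrogen gives a number 38 percentage points higher from compound 2 to compound 3 (beyond the scatter) and also a number 34 percentage points higher from compound 1 to compound 3 (beyond the scatter), so the antiproliferative effect at the one concentration tested is clearly weaker, even though both chains hold the same number of heavy atoms. The information available does not bear on the cause of this step.

The exchange adds a hydroxyl and removes a methyl at once, so the compounds shown leave open how much of the step belongs to each part of the change. They also leave open how this assay would read with an amine, a carboxylic acid or a longer chain carrying a single hydroxyl in place of the 1,2-dihydroxyethyl on the shared core.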